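The source may report more compounds than this note shows. Statements on the series, on what has been measured and on what is new or still open speak of the compounds shown alone.

Measured so far:
compound 1, `N/C(=N\NC(=S)N1CCOCC1)c1ccccn1`, 29.2%;
compound 2, `Cc1ccnc(/C(N)=N/NC(=S)N2CCN(c3ccccn3)CC2)c1`, 28.9%;
compound 3, `Cc1cccc(/C(N)=N/NC(=S)N2CCOCC2)n1`, 47.2%.

In a functional assay on A-431 cells (Homo sapiens) for cytotoxicity, read by MTT assay, with a stated time of 72 h, tested at 1 uM (a lower number here means less inhibition of growth, a higher number more inhibition of growth at the concentration tested), compound 3 gives 47.2%, and the change hydrogen in place of methyl on an aromatic carbon produces a number 18 percentage points lower from compound 3 to compound 1 (beyond the scatter). Compound 2 gives 28.9% in this assay, a value within the scatter of compound 1; the difference between the cores of compound 2 and compound 3 is not broken down here. Compound 4, `N/C(=N\NC(=S)N1CCN(c2ccccn2)CC1)c1ccccn1`, is still to be measured, and it arises from compound 2 through (hydrogen in place of methyl on an aromatic carbon). Among the measured compounds shown here, this is the same kind of change as the one from compound 3 to compound 1, but the place differs: there the carbon was next to the ring nitrogen, here it is opposite the ring nitrogen. Since compound 2 already sits close to compound 1 despite its methyl, the step is expected to be smaller than the earlier one, about a number 5.9 percentage points lower from compound 2 to compound 4 (within the scatter), with compound 4 expected near 23%, between 10% and 36%.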

Compound 4, percent growth inhibition at one concentration: 11.6%
Compound 4: middle estimate off by 11.4 percentage points, on the high side; measured number inside the range.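

In this assay, replacing the methyl with hydrogen gives a number 17.3 percentage points lower from compound 2 to compound 4 (beyond the scatter) and, set beside the earlier case, the change carries over between the two cores with much the same size: the same change on two cores in this assay, a number 18 percentage points lower (beyond the scatter) from compound 3 to compound 1 and a number 17.3 percentage points lower (beyond the scatter) from compound 2 to compound 4, 0.7 percentage points apart, within the scatter of two such steps. This rests on two cores only, and the methyl does not stand at the same place in both: in compound 2 it sits opposite the ring nitrogen, in compound 3 elsewhere on the ring. The two pairs show that losing the methyl lowered the number both times, not that it would do so on every core, and they do not show why.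

The compounds shown leave open whether an ethyl group, a methoxy group or a chlorine opposite the ring nitrogen would give a number like that of the methyl. They also leave open whether a methyl at both places on one ring would add up.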